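The source may report more compounds than this note shows. Statements on the series, on what has been measured and on what is new or still open speak of the compounds shown alone.

Three compounds share one core and differ only in the group on a carbonyl carbon. Compound 1 `Cn1cncc1CN1CC(N(CC2CCN(C(=O)c3ccc(Cl)cc3)CC2)S(=O)(=O)c2ccccn2)Cc2cc(C#N)ccc21` gives 0.5 10^-6 cm/s in an ADME assay on Caco-2 cells (Homo sapiens) for permeability, in the apical to basolateral direction; on this read-out higher numbers stand for higher permeability and lower numbers for lower permeability. Compound 2 `Cn1cncc1CN1CC(N(CC2CCN(C(=O)C3CCCC3)CC2)S(=O)(=O)c2ccccn2)Cc2cc(C#N)ccc21` gives 0.5 10^-6 cm/s in this assay, and compound 3 `CC(C)NC(=O)N1CCC(CN(C2Cc3cc(C#N)ccc3N(Cc3cncn3C)C2)S(=O)(=O)c2ccccn2)CC1` gives 0.6 10^-6 cm/s. Compound 2 thus stands level with compound 1 at the digits shown, the two together the lowest of the three numbers, and compound 3 lies nearest within the scatter.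

Compound 4 `Cn1cncc1CN1CC(N(CC2CCN(C(=O)c3ccco3)CC2)S(=O)(=O)c2ccccn2)Cc2cc(C#N)ccc21` is not yet measured. It differs from compound 2 as follows: furan-2-yl in place of cyclopentyl on a carbonyl carbon. Among the measured compounds shown here, the steps that bear on this change are no change at the digits printed from compound 1 to compound 2 (within the scatter) and a 1.2-fold higher number from compound 2 to compound 3 (0.08 log units; within the scatter), both within the scatter. Compound 4 is therefore expected to show no change at the digits printed from compound 2 to compound 4 (within the scatter), no change beyond the scatter. The estimate for compound 4 is 0.5 10^-6 cm/s, in the range 0.25 10^-6 cm/s to 1 10^-6 cm/s.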

Compound 4, apparent permeability: 0.5 10^-6 cm/s
Compound 4: middle estimate and measured number agree at the digits printed; measured number inside the range.
By their numbers in this assay, from the lowest: compounds 1, 2, 4 and 3 (each within the scatter of the next).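

Furan-2-yl on a carbonyl carbon brings an aromatic ring, a ring oxygen and a hydrogen-bond acceptor in place of cyclopentyl, yet this assay shows no step beyond the scatter (no change at the digits printed from compound 2 to compound 4 (within the scatter)). The same holds against the two other groups (no change at the digits printed from compound 1 to compound 4 (within the scatter); a 1.2-fold lower number from compound 3 to compound 4 (0.08 log units; within the scatter)), so all four groups at this position lie within the scatter of one another. Nothing available explains this flat reading. The compounds shown leave open whether an amine, a carboxylic acid or a longer chain here would move the number beyond the scatter.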